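The source may report more compounds than this note shows. Statements on the series, on what has been measured and on what is new or still open speak of the compounds shown alone.

Values so far in a functional assay for inhibition, with Rattus norvegicus as the target; on this read-out lower numbers stand for stronger inhibition and higher numbers for weaker inhibition

compound 1 `CCc1cc(C#N)ccc1C/N=c1\c(O)c(O)\c1=N/C(C)(C)C`: 240 nM
compound 2 `CC(C)(C)/N=c1\c(O)c(O)\c1=N/Cc1ccccc1`: 3400 nM

Compound 2 (3400 nM) has the higher of the two numbers, which makes it the weaker inhibitor of the pair, and its gap to compound 1 lies beyond the scatter. Compound 3 `CC(C)(C)/N=c1\c(O)c(O)\c1=N/Cc1ccc(C#N)cc1` is compound 2 with one change: cyano in place of hydrogen on an aromatic carbon, para to a large group (cyano in place of hydrogen on an aromatic carbon). Going by the values given here, no measured pair shows this change alone. Going by these compounds, compound 1 (240 nM) also holds a cyano, together with an ethyl, so how much of its lower number goes with the cyano is unknown. A drop in the number beyond the scatter is expected, probably stopping short of compound 1. In size, the expected change is a 4.3-fold lower number from compound 2 to compound 3 (0.63 log units; beyond the scatter) in this assay for this single swap. For compound 3 the estimate is 800 nM with an expected range (280 nM to 2300 nM).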

Compound 3, half-maximal inhibitory concentration: 270 nM
The estimate for compound 3 lay 3.0-fold (0.47 log units) above the measured number; the whole stated range lies above it.
By their numbers in this assay, from the lowest: compounds 1 and 3 (each within the scatter of the next); then compound 2.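

In this assay, adding a cyano group at this place on the aromatic ring is enough on its own to produce a large change (a 13-fold lower number from compound 2 to compound 3 (1.10 log units; beyond the scatter)). The ethyl group of compound 1 can now be judged separately, and with the cyano group present it makes no difference that stands out from the scatter (a 1.1-fold higher number from compound 1 to compound 3 (0.05 log units; within the scatter)). Nothing shown here explains why the cyano group has so large an effect.

Going by these compounds, it remains open whether this drop is specific to the cyano group, or whether another group at this place, such as a carboxylic acid, a chlorine atom or a methoxy group, would give a similar number. On these data alone, it is also open whether an ethyl group would change the number on a ring that has no cyano group.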